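A few compounds are considered here, and "the series" means these few. Any claim that something is new, unique, unknown or untested is made for them only; others in the source may bear on it.

Of the compounds shown here, three that share one core have been measured in a functional assay on A549 cells (Homo sapiens) for cytotoxicity, read by MTT assay, with a stated time of 72 h; a higher number here means a weaker inhibitor, a lower number a stronger inhibitor: compound 1 `COc1cc2ncnc(Nc3ccc(F)c(Cl)c3)c2cc1NC(=O)N/N=C/c1ccc(F)cc1` gives 26600 nM, compound 2 `COc1cc2ncnc(Nc3ccc(F)c(Cl)c3)c2cc1NC(=O)N/N=C/c1cccc(Br)c1` gives 28100 nM and compound 3 `COc1cc2ncnc(Nc3ccc(F)c(Cl)c3)c2cc1NC(=O)N/N=C/c1ccc(C#N)cc1` gives 32200 nM. Compound 3 stands level with the other two, as the steps show: a 1.2-fold higher number from compound 1 to compound 3 (0.08 log units; within the scatter) and a 1.1-fold higher number from compound 2 to compound 3 (0.06 log units; within the scatter).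

The next compound, compound 4 `COc1cc2ncnc(Nc3ccc(F)c(Cl)c3)c2cc1NC(=O)N/N=C/c1ccc([N+](=O)[O-])cc1`, differs from compound 3 in one place: nitro in place of cyano on an aromatic carbon. In words, this is nitro in place of cyano on an aromatic carbon, para to a large group.

Within the data shown here, no measured compound carries a nitro group, so no direct precedent exists. The nearest guide is the earlier exchange at the same kind of carbon, a 1.2-fold higher number from compound 1 to compound 3 (0.08 log units; within the scatter). The change to a different substituted phenyl, a 1.1-fold higher number from compound 1 to compound 2 (0.02 log units; within the scatter), points the same way. Each of these steps stayed within the scatter, so no step beyond the scatter is expected here in this assay.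

The expected step is a 1.2-fold lower number from compound 3 to compound 4 (0.06 log units; within the scatter). Compound 4 is therefore estimated at about 28000 nM, with a likely range of 14000 nM to 55000 nM.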

Compound 4, half-maximal inhibitory concentration: 35100 nM
Estimate against measurement, compound 4: 1.3-fold (0.10 log units) below; measured number inside the range.
By their numbers in this assay, from the lowest: compounds 1, 2, 3 and 4 (each within the scatter of the next).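

Putting a nitro group where the nitrile stood, on an aromatic carbon para to a large group, leaves the reading in this assay within the scatter (a 1.1-fold higher number from compound 3 to compound 4 (0.04 log units; within the scatter)). Among these compounds, the nitro compound also stays within the scatter of the compounds carrying the other two substituted phenyl groups (a 1.2-fold higher number from compound 2 to compound 4 (0.10 log units; within the scatter); a 1.3-fold higher number from compound 1 to compound 4 (0.12 log units; within the scatter)), so a fourth group at this end of the molecule, with different atoms from the first three, still sets no compound apart. Nothing measured here explains why these four compounds read so alike.

As far as these compounds go, it remains open whether an amine, a carboxylic acid or a longer chain on this ring would move the number beyond the scatter. From the compounds shown here alone, it is also open whether the same flat picture would hold with a different link between this ring and the shared core.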